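The compounds below may be only part of what the source reports. "The series", "measured", "known", "first", "only" and "open" are said of these compounds alone.

Measured so far in an ADME assay on MT4 cells (Homo sapiens) for cytotoxicity, read by MTT assay, with a stated time of 5 days; on this read-out lower numbers stand for higher toxicity in this test and higher numbers for lower toxicity in this test:
Compound 1 `Cc1cc(C#N)cc(C)c1Oc1nc(Nc2ccc(C#N)cc2)ncc1-c1ccc(C(F)(F)F)cc1` gives 35000 nM.
Compound 2 `Cc1cc(C#N)cc(C)c1Oc1nc(Nc2ccc(C#N)cc2)ncc1-c1cccs1` gives 6430 nM.

For the measured compounds named here, compound 2 holds the lower of the two numbers in this assay, the only other number being reached by a 5.4-fold lower number from compound 1 to compound 2 (0.74 log units; beyond the scatter). Compound 3 `Cc1cc(C#N)cc(C)c1Oc1nc(Nc2ccc(C#N)cc2)ncc1-c1ccncc1` differs from compound 2 by pyridin-4-yl in place of thiophen-2-yl on an aromatic carbon. Going by the values given here, the one measured step that bears on this change, an exchange of the aryl group at the same place, is a 5.4-fold lower number from compound 1 to compound 2 (0.74 log units; beyond the scatter), a modest one, and the pyridin-4-yl group itself is untested, so the direction remains open. Compound 3 is therefore expected near 15000 nM, within 4000 nM to 50000 nM, which would be an expected 2.3-fold higher number from compound 2 to compound 3 (0.37 log units; beyond the scatter).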

Compound 3, half-maximal cytotoxic concentration: 28000 nM
Compound 3: the middle estimate sits 1.9-fold (0.27 log units) below what was measured; the measured number falls inside the stated range.
By their numbers in this assay, from the lowest: compound 2; then compounds 3 and 1 (each within the scatter of the next).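

In this assay, the change at this place, para to a (4-cyanophenyl)amino group, gives a 4.4-fold higher number from compound 2 to compound 3 (0.64 log units; beyond the scatter) and so moves the number away from that of the thiophen-2-yl compound. The two six-membered aryl groups, by contrast, stay within the scatter of each other, with a 1.3-fold lower number from compound 1 to compound 3 (0.10 log units; within the scatter) despite the different rings, so among these three compounds only the thiophen-2-yl compound stands apart and none goes against that split. Nothing given here accounts for the difference.

As far as these compounds go, whether the five-membered ring or its sulfur goes with the lower number stays open. A furan-2-yl or thiophen-3-yl group at this place would separate the two, and a saturated amine such as morpholine would extend the comparison beyond aromatic rings.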